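This account rests on a few compounds, and the source may have more. Where it says the series, first, only, none or still open, it means among the compounds named here.

Compound 1 `COc1ccc(-n2cc(CNCCN3CCN(C)CC3)c(-c3ccccc3C)n2)cc1`: > 20000 nM
Compound 2 `CN1CCN(CCNCc2cn(-c3ccc(F)cc3F)nc2-c2ccc(S(=O)(=O)N(C)C)cc2)CC1`: > 20000 nM
Compound 3 `CN1CCN(CCNCc2cn(-c3ccc(F)cc3F)nc2C2CCCCC2)CC1`: > 20000 nM

In an ADME assay on Huh-7 cells (Homo sapiens) for cytotoxicity (on this read-out higher numbers stand for lower toxicity in this test and lower numbers for higher toxicity in this test), compound 1 gives > 20000 nM, which is a limit of the assay and not a number. Compound 2 gives > 20000 nM, also a limit. Compound 3 gives > 20000 nM, again a limit. For the measured compounds named here, the only step between measured compounds, a step that the two limits leave unreadable from compound 2 to compound 3, therefore cannot be read, since (the limit of > 20000 nM in this assay, at which 3 of the 3 values shown sit). Compound 4 `CSc1ccc(-n2cc(CNCCN3CCN(C)CC3)c(-c3ccccc3C)n2)cc1` differs from compound 1 in one place: methylsulfanyl in place of methoxy on an aromatic carbon. Going by the values given here, no measured step bears on this change, so the expectation rests only on compound 1 standing at the limit, and the step that the limit leaves unreadable from compound 1 to compound 4 is expected to stay within the scatter. Compound 4 is estimated at 25000 nM, with a range from 10000 nM to 60000 nM, most likely reported as a limit once more.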

Compound 4, half-maximal cytotoxic concentration: 17000 nM
Beside the measured number, compound 4's estimate is 1.5-fold (0.17 log units) above it; low and high end bracket the measured number.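

Methylsulfanyl in place of methoxy on this aromatic carbon gives the first read-out here that is a number and not a limit: in this assay, compound 4 gives 17000 nM. The change amounts to an at least 1.1-fold lower number from compound 1 to compound 4 (0.07 log units; that floor lies within the scatter), so the data show no step beyond the scatter. Its full size stays unreadable: the limit of > 20000 nM in this assay, at which 3 of the 4 values shown sit.

Going by these compounds, how an amine, a carboxylic acid or a longer chain on this same carbon would read in this assay remains open. So does whether methylsulfanyl would give a number on other parts of the series.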